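Ketone to alcohol on the compound 1 side chain

The compounds below may be only part of what the source reports. "The series", "measured", "known", "first", "only" and "open" are said of these compounds alone.

Values in a functional assay on Caco-2 cells (Homo sapiens), read by MTT assay, with a stated time of 48 h (a lower number here means a stronger inhibitor, a higher number a weaker inhibitor), as measured so far
Compound 1 `CCN(CC)CCNC(=O)c1ccc(C(CC)(CC)c2ccc(OCC(=O)C(C)(C)C)c(C)c2)n1CC`: 1600 nM
Compound 2 `CCn1c(C(=O)NCCN)ccc1C(CC)(CC)c1ccc(OCC(=O)C(C)(C)C)c(C)c1`: 1900 nM

Among the compounds with values here, compound 1 stands within the scatter of compound 2, the only other measured compound. Compound 3 `CCN(CC)CCNC(=O)c1ccc(C(CC)(CC)c2ccc(OCC(O)C(C)(C)C)c(C)c2)n1CC` differs from compound 1 by 1-hydroxy-2,2-dimethylpropyl in place of (tert-butyl)carbonyl on a saturated chain carbon bound to an oxygen on an aromatic ring and the change falls on a saturated chain carbon bound to an oxygen on an aromatic ring. Within the data shown here, the one measured step of a 1.2-fold higher number from compound 1 to compound 2 (0.07 log units; within the scatter) concerns the diethylamino group and not this place, so no measurement covers the change directly. No step beyond the scatter is expected in this assay and the range stays wide. The estimate is a 1.1-fold lower number from compound 1 to compound 3 (0.03 log units; within the scatter) as the expected step. For compound 3 the expected value is 1500 nM as the estimate, with 600 nM to 3800 nM as its range.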

Compound 3, half-maximal inhibitory concentration: 2310 nM
Compound 3: the middle estimate sits 1.5-fold (0.19 log units) below what was measured; the range from low to high includes it.
By their numbers in this assay, from the lowest: compounds 1, 2 and 3 (each within the scatter of the next).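

Measured in this assay on a saturated chain carbon bound to an oxygen on an aromatic ring, 1-hydroxy-2,2-dimethylpropyl in place of (tert-butyl)carbonyl gives a 1.4-fold higher number from compound 1 to compound 3 (0.16 log units; within the scatter) and so no step beyond the scatter. This place therefore accepts the added hydrogen-bond donor and the loss of the double bond without a readable change, as the diethylamino place did for its exchange. No measurement at hand explains this result.

Still open, from the compounds shown here alone, is whether a carboxylic acid, an amine or a longer chain at this place would move the number beyond the scatter. Also open, going by these compounds, is how amino in place of diethylamino reads with 1-hydroxy-2,2-dimethylpropyl present.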